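Neopentyl to tert-butyl: working notes on the series

This account rests on a few compounds, and the source may have more. Where it says the series, first, only, none or still open, it means among the compounds named here.

Measured in a functional assay on a cell-free system (plasma, Homo sapiens), with a stated time of 3 min; a higher number here means a weaker inhibitor, a lower number a stronger inhibitor:
- compound 1 `O=C(NCc1cc(Cl)ccc1-n1cnnn1)[C@@H]1C[C@H]2C[C@H]2N1C(=O)[C@H](O)CC1CC1`: 850 nM
- compound 2 `O=C(NCc1cc(Cl)ccc1-n1cnnn1)[C@@H]1C[C@H]2C[C@H]2N1C(=O)[C@H](O)c1ccccc1`: 680 nM
- compound 3 `CC(C)(C)C[C@@H](O)C(=O)N1[C@@H]2C[C@@H]2C[C@H]1C(=O)NCc1cc(Cl)ccc1-n1cnnn1`: 520 nM

Compound 3, at 520 nM, cannot be separated from either of the other two compounds, as its value lies within the scatter of both. The next compound is compound 4 `CC(C)(C)[C@@H](O)C(=O)N1[C@@H]2C[C@@H]2C[C@H]1C(=O)NCc1cc(Cl)ccc1-n1cnnn1`, which has tert-butyl in place of neopentyl on a saturated chain carbon bound to a carbonyl carbon and an oxygen on a saturated carbon.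

Among the measured compounds shown here, three measured steps bear on this change, all of them swaps in the same side chain. They are a 1.3-fold lower number from compound 1 to compound 2 (0.10 log units; within the scatter), a 1.6-fold lower number from compound 1 to compound 3 (0.21 log units; within the scatter) and a 1.3-fold lower number from compound 2 to compound 3 (0.12 log units; within the scatter). Each lies within the scatter, and none of the three compounds goes against that picture. For the measured compounds named here, no measured compound carries tert-butyl on that carbon, so this exact swap has no direct precedent, and the range is kept wide. A step beyond the scatter is not expected in this assay, and no direction is favoured. The estimated step is a 1.2-fold higher number from compound 3 to compound 4 (0.06 log units; within the scatter). The estimate for compound 4 is 600 nM, with an expected range from 200 nM to 1800 nM.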

Compound 4, half-maximal inhibitory concentration: 1100 nM
For compound 4 the middle estimate is 1.8-fold (0.26 log units) below the measured one; the range from low to high includes it.
By their numbers in this assay, from the lowest: compounds 3, 2, 1 and 4 (each within the scatter of the next, the first and the last beyond it).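

In this assay the change from neopentyl to tert-butyl gives a 2.1-fold higher number from compound 3 to compound 4 (0.33 log units; beyond the scatter), the only step among these compounds that lies beyond the scatter, so this position does respond to a change of side chain, even one as small as going from 5 heavy atoms to 4. The response is limited: a 1.6-fold higher number from compound 2 to compound 4 (0.21 log units; within the scatter) and a 1.3-fold higher number from compound 1 to compound 4 (0.11 log units; within the scatter) both stay within the scatter, so tert-butyl separates only from neopentyl and cannot be told apart from phenyl or cyclopropylmethyl on that carbon. The compounds shown offer no measurement that accounts for the gap between neopentyl and tert-butyl.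

Still open, as far as these compounds go, is whether a longer chain than neopentyl on this carbon would move the number further in the same direction as the step from tert-butyl to neopentyl or would leave it within the scatter. An amine or a carboxylic acid at the end of the side chain is also untested in these compounds, so the tolerance of this position for such groups cannot be judged from the data shown.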